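Ring size of the carbamate alcohol: oxolane to oxane

A few compounds are considered here, and "the series" means these few. Any claim that something is new, unique, unknown or untested is made for them only; others in the source may bear on it.

Among the measured compounds shown here, compound 2 `C[C@@H](CNc1ccc(OC(F)(F)F)cc1)NC(=O)[C@H](CC1CCCCC1)NC(=O)O[C@@H]1CCOC1` gives 42 nM in an assay on isolated protein for inhibition of cathepsin S (Homo sapiens) (on this read-out lower numbers stand for stronger inhibition and higher numbers for weaker inhibition), the top of the two numbers so far, though its distance from compound 1 `C[C@@H](CNc1ccc(OC(F)(F)F)cc1)NC(=O)[C@H](CC1CCCCC1)NC(=O)C1CCOC1`, which gives 21 nM in this assay, lies within the scatter: a 2.0-fold higher number from compound 1 to compound 2 (0.30 log units; within the scatter). Compound 3 `C[C@@H](CNc1ccc(OC(F)(F)F)cc1)NC(=O)[C@H](CC1CCCCC1)NC(=O)OC1CCOCC1` differs from compound 2 by oxan-4-yl in place of oxolan-3-yl on an oxygen next to a carbonyl group. For the measured compounds named here, no measured step bears on this change; the single step available alters a different part of the molecule and was itself within the scatter, so in this assay no movement beyond the scatter is expected, a 1.1-fold higher number from compound 2 to compound 3 (0.03 log units; within the scatter). Compound 3 is therefore estimated at 45 nM, with a range from 15 nM to 135 nM.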

Compound 3, inhibition constant: 12 nM
Estimate against measurement, compound 3: 3.8-fold (0.57 log units) above; the measured number lies below the stated range.
By their numbers in this assay, from the lowest: compounds 3, 1 and 2 (each within the scatter of the next, the first and the last beyond it).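

Among the compounds shown here, on the oxygen next to a carbonyl group, ring size matters in a way the earlier compounds could not show: oxan-4-yl in place of oxolan-3-yl is the only step here beyond the scatter (a 3.5-fold lower number from compound 2 to compound 3 (0.54 log units; beyond the scatter)). Compound 3 nevertheless remains within the scatter of the compound with oxolan-3-yl directly on the carbonyl carbon (a 1.8-fold lower number from compound 1 to compound 3 (0.24 log units; within the scatter)). Nothing available accounts for the difference between the two rings.

The compounds shown leave open how a plain cyclohexyl or an amine such as piperidin-4-yl would read on that oxygen. They also leave open how the opposite configuration of oxolan-3-yl would compare.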